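From 3-fluorophenyl to 2,4-difluorophenyl on a shared core

The compounds below may be only part of what the source reports. "The series", "measured", "known", "first", "only" and "open" are said of these compounds alone.

In a functional assay on Jurkat cells (Homo sapiens) (on this read-out higher numbers stand for weaker inhibition and lower numbers for stronger inhibition), compound 1 `CC(C)[C@H](NC(=O)COc1cccc2ccccc12)C(=O)N[C@@H](CC(=O)O)C(=O)COc1ccc(OC(F)(F)F)cc1` gives 29100 nM. Compound 2 `CC(C)[C@H](NC(=O)COc1cccc2ccccc12)C(=O)N[C@@H](CC(=O)O)C(=O)COc1cccc(F)c1` gives > 100000 nM, and this is a limit of the assay, not a number. The two compounds differ only in the group on an oxygen on a saturated carbon, where compound 2 has 3-fluorophenyl and compound 1 has 4-(trifluoromethoxy)phenyl.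

Compound 3 `CC(C)[C@H](NC(=O)COc1cccc2ccccc12)C(=O)N[C@@H](CC(=O)O)C(=O)COc1ccc(F)cc1F` has the same core but carries 2,4-difluorophenyl in place of the 3-fluorophenyl of compound 2: 2,4-difluorophenyl in place of 3-fluorophenyl on an oxygen on a saturated carbon.

Among the compounds with values here, only one measured step bears on this change. It sits at the same place and swaps a different pair of groups, so it offers only a rough guide. That step is an at least 3.4-fold higher number from compound 1 to compound 2 (0.53 log units; beyond the scatter), which shows that a change of group here can move the read-out beyond the scatter. Compound 3 also lacks the 4-(trifluoromethoxy)phenyl group, so it is expected to remain weak in this assay, perhaps with a slightly lower number than the limit of compound 2. The estimated change is an at least 1.4-fold lower number from compound 2 to compound 3 (0.15 log units; that floor lies within the scatter). For compound 3 the expected value is 70000 nM, with an estimated range of 25000 nM to 200000 nM.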

Compound 3, half-maximal inhibitory concentration: 33200 nM
Compound 3: middle estimate off by 2.1-fold (0.32 log units), on the high side; low and high end bracket the measured number.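

In this assay, putting 2,4-difluorophenyl in place of 3-fluorophenyl on the oxygen gives an at least 3.0-fold lower number from compound 2 to compound 3 (0.47 log units; beyond the scatter), so a phenyl ring carrying only fluorine at this position can still give a measurable value. From the compounds shown here alone, this step has only a floor, and its true size is unknown, as compound 2 gives a limit of the assay and not a number: the limit of > 100000 nM in this assay, at which 1 of the 3 values shown sits. Within the data shown here, the comparison with the other measured group shows a 1.1-fold higher number from compound 1 to compound 3 (0.06 log units; within the scatter), so the 4-(trifluoromethoxy)phenyl group is not the only group here that gives a measurable value, and these two groups cannot be told apart on this read-out.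

What remains open is which fluorine matters, as the 2,4-difluorophenyl group differs from the 3-fluorophenyl group in the places of its fluorines as well as in their count, and the compounds shown cannot separate these two differences. A plain phenyl, a 2-fluorophenyl or a 4-fluorophenyl group on the same oxygen would be the direct test, and a 4-methoxyphenyl group would show whether the fluorines of the 4-(trifluoromethoxy)phenyl group count at all.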